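Trimming the Thiourea Arm: Dropping the Trifluoromethyl

This account rests on a few compounds, and the source may have more. Where it says the series, first, only, none or still open, it means among the compounds named here.

Of the compounds shown here, two sharing one core have been tested in a functional assay on HCT-116 cells (Homo sapiens) for cytotoxicity, read by MTT assay, with a stated time of 48 h; a lower number here means a stronger inhibitor, a higher number a weaker inhibitor. Compound 1 `CNC(=O)c1ccc(Sc2ccc(NC(=S)Nc3ccc(F)c(F)c3)cc2)nc1` gives 22200 nM. Compound 2 `CNC(=O)c1ccc(Sc2ccc(NC(=S)Nc3ccc(Cl)c(C(F)(F)F)c3)cc2)nc1` gives 4900 nM, the lower of the two numbers, and its gap to compound 1 lies beyond the usual scatter, so on these two numbers compound 2 is the stronger inhibitor. Compound 3 `CNC(=O)c1ccc(Sc2ccc(NC(=S)Nc3ccc(Cl)cc3)cc2)nc1` is the next to be measured in this assay. It differs from compound 2 in one place: hydrogen in place of trifluoromethyl on an aromatic carbon. For the measured compounds named here, no two measured compounds differ only in this way, so the size of the step has no measured anchor. Compound 1 carries different groups on that same ring and sits at 22200 nM, which shows that this ring end matters; the expected direction is toward a higher number, beyond the scatter. The expected step is a 2.4-fold higher number from compound 2 to compound 3 (0.39 log units; beyond the scatter). The estimate for compound 3 is 12000 nM, with a range from 5000 nM to 30000 nM.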

Compound 3, half-maximal inhibitory concentration: 34500 nM
Beside the measured number, compound 3's estimate is 2.9-fold (0.46 log units) below it; measured number outside the range, above it.
By their numbers in this assay, from the lowest: compound 2; then compounds 1 and 3 (each within the scatter of the next).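

In this assay, the swap of trifluoromethyl for hydrogen now has a measured size: a 7.0-fold higher number from compound 2 to compound 3 (0.85 log units; beyond the scatter), so this position on the ring strongly affects the result when a chloro group is also present. The chloro group alone does not hold the lower number of compound 2, since comparing the two ring ends gives a 1.6-fold higher number from compound 1 to compound 3 (0.19 log units; within the scatter), which means the 4-chlorophenyl and 3,4-difluorophenyl ends cannot be told apart in this assay. Nothing measured here explains why removing trifluoromethyl has such an effect.

On these data alone, it remains open whether trifluoromethyl itself is needed or whether another group at the same place, such as methyl, a nitrile or a methoxy group, would serve as well. As far as these compounds go, the share of the chloro group in the number of compound 2 also remains open.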